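Aryl variation on a fused bicyclic fatty acid receptor agonist

The source may report more compounds than this note shows. Statements on the series, on what has been measured and on what is new or still open speak of the compounds shown alone.

Measured compounds:
compound 1 `CC#CC(CC(=O)O)c1ccc(OCc2ccc3nc(-c4ccc(C(F)(F)F)cc4)cn3c2)cc1`: 558 nM
compound 2 `CC#CC(CC(=O)O)c1ccc(OCc2ccc3nc(-c4ccc(F)cc4F)cn3c2)cc1`: 825 nM
compound 3 `CC#CC(CC(=O)O)c1ccc(OCc2ccc3nc(-c4ccc(C5CCCCC5)cc4)cn3c2)cc1`: 417 nM

Three compounds sharing one core were examined in an assay on isolated protein for agonist activity at Free fatty acid receptor 1 (Homo sapiens); a higher number here means that more compound is needed for the effect, a lower number that less compound is needed. Compound 1 gives 558 nM in this assay, compound 2 gives 825 nM, and compound 3 gives 417 nM. Compound 3 stands at the low end of the three numbers, yet the steps of a 1.3-fold lower number from compound 1 to compound 3 (0.13 log units; within the scatter) and a 2.0-fold lower number from compound 2 to compound 3 (0.30 log units; within the scatter) are both within the scatter, as is a 1.5-fold higher number from compound 1 to compound 2 (0.17 log units; within the scatter). Every change made so far at this aromatic carbon of the fused system has therefore left this assay essentially unmoved.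

Compound 4 `CC#CC(CC(=O)O)c1ccc(OCc2ccc3nc(-c4cccc(C)c4)cn3c2)cc1` continues the series at the same place: 3-methylphenyl in place of 4-cyclohexylphenyl on an aromatic carbon. Within the data shown here, the steps that bear on it, from compound 1, compound 2 and compound 3, all varied this same aryl group and none moved the number beyond the scatter. Compound 4 is therefore expected to show a step of a 1.7-fold higher number from compound 3 to compound 4 (0.22 log units; within the scatter), without a clear direction beyond the scatter. The estimated value for compound 4 is 700 nM, with a range from 300 nM to 1600 nM.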

Compound 4, half-maximal effective concentration: 1050 nM
The estimate for compound 4 lay 1.5-fold (0.18 log units) below the measured number; the measured number falls inside the stated range.
By their numbers in this assay, from the lowest: compounds 3, 1, 2 and 4 (each within the scatter of the next, the first and the last beyond it).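

In this assay, among these compounds, the exchange of 4-cyclohexylphenyl for 3-methylphenyl (a 2.5-fold higher number from compound 3 to compound 4 (0.40 log units; beyond the scatter)) is the only step at this aromatic carbon that lies beyond the scatter, so the aryl group here can shift the number, though only modestly. That shift appears between these two compounds alone: compound 4 stays within the scatter of the two remaining compounds (a 1.3-fold higher number from compound 2 to compound 4 (0.10 log units; within the scatter); a 1.9-fold higher number from compound 1 to compound 4 (0.27 log units; within the scatter)), so the four do not divide into two clear groups. No measurement is available that would explain the step.

The compounds shown leave open whether the step follows the loss of the cyclohexyl ring or the different place of the substituent on the phenyl ring, a question that 4-methylphenyl or 3-cyclohexylphenyl would separate. On these data alone, how an amine or a carboxylic acid on that phenyl ring would behave also remains open.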